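The source may hold more compounds than are shown below. What is called first, only, known or untested is meant among the compounds shown, and "the series" means these compounds.

Measured compounds:
Compound 1 `COc1cc(N(C)CCN(C)C)c(NC(=O)/C=C\C(C)C)cc1Nc1nccc(-c2cn(C)c3ccccc23)n1` — 612 nM
Compound 2 `CCC/C=C\C(=O)Nc1cc(Nc2nccc(-c3cn(C)c4ccccc34)n2)c(OC)cc1N(C)CCN(C)C` — 808 nM
Compound 3 `COc1cc(N(C)CCN(C)C)c(NC(=O)/C=C\C(C)C)cc1Nc1ncc(C#N)c(-c2cn(C)c3ccccc23)n1` — 1100 nM

Of the compounds shown here, three have been measured in a functional assay on A549 cells (Homo sapiens) for antiproliferative activity, read by MTT assay, with a stated time of 72 h; on this read-out higher numbers stand for weaker inhibition and lower numbers for stronger inhibition. Compound 1 gives 612 nM. Compound 2 differs from it by propyl in place of isopropyl on a double-bonded chain carbon bound to a double-bonded chain carbon and gives 808 nM, a step of a 1.3-fold higher number from compound 1 to compound 2 (0.12 log units; within the scatter). Compound 3 differs in its core by cyano in place of hydrogen on an aromatic carbon from the first compound, and compound 3 gives 1100 nM, a step of a 1.8-fold higher number from compound 1 to compound 3 (0.25 log units; within the scatter). Compound 3 holds the highest of the three numbers, but its distance to the other two lies within the scatter, so no order among them can be read from these values.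

Compound 4 `CCC/C=C\C(=O)Nc1cc(Nc2ncc(C#N)c(-c3cn(C)c4ccccc34)n2)c(OC)cc1N(C)CCN(C)C` has not yet been measured. It differs from compound 3 by propyl in place of isopropyl on a double-bonded chain carbon bound to a double-bonded chain carbon. This is the same change that carries compound 1 to compound 2, made here on the core that carries the cyano group; the place of the change is described in the same words in both pairs. Going by the values given here, the only guide is the earlier step, a 1.3-fold higher number from compound 1 to compound 2 (0.12 log units; within the scatter), which lay within the scatter. If the change behaves on the core of compound 3 as it did on the core of compound 1, compound 4 is expected to sit close to compound 3, with a step of about a 1.3-fold higher number from compound 3 to compound 4 (0.10 log units; within the scatter). On this basis compound 4 is estimated at 1400 nM in this assay, with a likely range from 700 nM to 2900 nM.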

Compound 4, half-maximal inhibitory concentration: 166 nM
Compound 4: middle estimate off by 8.4-fold (0.93 log units), on the high side; measured number below the stated range.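

In this assay, propyl in place of isopropyl on a double-bonded chain carbon bound to a double-bonded chain carbon gives a 6.6-fold lower number from compound 3 to compound 4 (0.82 log units; beyond the scatter) on the core that carries the cyano group, so the step seen on the core without it did not carry over: the same change on two cores in this assay, a 1.3-fold higher number (0.12 log units; within the scatter) from compound 1 to compound 2 and a 6.6-fold lower number (0.82 log units; beyond the scatter) from compound 3 to compound 4, 8.7-fold (0.94 log units) apart, beyond the scatter of two such steps.
Read the other way, cyano in place of hydrogen on an aromatic carbon gives a 4.9-fold lower number from compound 2 to compound 4 (0.69 log units; beyond the scatter) when the propyl chain is present, which differs from what the same exchange did with the isopropyl chain: the same change on two cores in this assay, a 1.8-fold higher number (0.25 log units; within the scatter) from compound 1 to compound 3 and a 4.9-fold lower number (0.69 log units; beyond the scatter) from compound 2 to compound 4, 8.7-fold (0.94 log units) apart, beyond the scatter of two such steps.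
Across these four compounds, then, the size and direction of each change depend on the other, but this rests on a single set of two cores and two chains in one cell assay, and it does not show why the two changes interact or whether the same would hold anywhere else in the series.

On these data alone, it remains open whether a longer chain such as butyl or pentyl in place of propyl would follow compound 4 on the cyano core, and whether the chain exchange would behave the same way with chloro or trifluoromethyl in place of cyano. As far as these compounds go, whether the same interplay would appear on cells other than those of this assay also stays open.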